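Fluoroalkyl variation on the aminopyrimidine arm

The source may report more compounds than this note shows. Statements on the series, on what has been measured and on what is new or still open speak of the compounds shown alone.

Measured compounds:
compound 1, `N#Cc1cnc(NCc2cnccc2C(F)(F)F)cc1NC[C@H]1CC[C@H](O)CC1`: 50 nM
compound 2, `CC(C)(F)c1ncncc1CNc1cc(N[C@H]2CC[C@@H](O)CC2)c(C#N)cn1`: 32 nM

In an assay on isolated protein for inhibition of protein kinase C theta type (Homo sapiens), read by TR-FRET, with a stated time of 2 h (a higher number here means a weaker inhibitor, a lower number a stronger inhibitor), compound 1 gives 50 nM and compound 2 gives 32 nM. The two numbers lie within the usual scatter of each other, so neither compound can be set apart in this assay on the present data.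

Compound 3, `N#Cc1cnc(NCc2cncnc2OCC(F)F)cc1N[C@H]1CC[C@@H](O)CC1`, has not yet been measured. It differs from compound 2 in one place: 2,2-difluoroethoxy in place of 1-fluoro-1-methylethyl on an aromatic carbon, on an aromatic carbon of a six-membered aromatic ring with two nitrogens, next to the ring nitrogen, ortho to a large group, opposite the ring nitrogen.

Among the measured compounds shown here, no step between measured compounds covers such a change, so nothing in the data sets its size or direction. For the measured compounds named here, with only this single change, the step from compound 2 to compound 3 is expected to be small, a 1.6-fold higher number from compound 2 to compound 3 (0.19 log units; within the scatter), not clearly beyond the scatter in either direction. For compound 3 the estimate in this assay is 50 nM, with a range from 15 nM to 160 nM.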

Compound 3, half-maximal inhibitory concentration: 90 nM
For compound 3 the middle estimate is 1.8-fold (0.26 log units) below the measured one; measured number inside the range.
By their numbers in this assay, from the lowest: compounds 2, 1 and 3 (each within the scatter of the next, the first and the last beyond it).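

Among the compounds shown here, on this aromatic carbon, 2,2-difluoroethoxy in place of 1-fluoro-1-methylethyl gives a 2.8-fold higher number from compound 2 to compound 3 (0.45 log units; beyond the scatter) in this assay and provides the only single-place step so far, modest in size. The position therefore responds to the group it carries: with 5 heavy atoms and 1 hydrogen-bond acceptor entering for 4 heavy atoms and 0 hydrogen-bond acceptors, the change goes toward a weaker inhibitor. Nothing at hand bears on the origin of this step.

The compounds shown leave open whether the oxygen or the number of fluorines carries the step, as both change together in this pair. Ethoxy or 2,2,2-trifluoroethoxy on the same carbon would separate these two changes.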